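Replacing a carboxy group with ethyl on the chain

The source may report more compounds than this note shows. Statements on the series, on what has been measured and on what is new or still open speak of the compounds shown alone.

Of the compounds shown here, three sharing one core have been tested in an assay on isolated protein for inhibition of serine protease 1 (Bos taurus); on this read-out lower numbers stand for stronger inhibition and higher numbers for weaker inhibition. Compound 1 `CC(=N)N1CCC(Oc2ccc3c(c2)nc(C(C)C)n3Cc2ccc3ccc(C(=N)N)cc3c2)CC1` carries an isopropyl group on the core and gives 16 nM. Compound 2 `CC(=N)N1CCC(Oc2ccc3c(c2)nc(CCC(=O)O)n3Cc2ccc3ccc(C(=N)N)cc3c2)CC1` carries a 2-carboxyethyl group in its place and gives 14 nM. Compound 3 `CCc1nc2ccc(OC3CCN(C(C)=N)CC3)cc2n1Cc1ccc2ccc(C(=N)N)cc2c1` carries an ethyl group and gives 7.7 nM. Among these three numbers compound 2 has the second highest, yet its nearest neighbour compound 1 and its furthest neighbour compound 3 both lie within the scatter of it, so no order can be read among them.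

Compound 4 `CCCCc1nc2cc(OC3CCN(C(C)=N)CC3)ccc2n1Cc1ccc2ccc(C(=N)N)cc2c1` is still to be measured in this assay. It differs from compound 2 in one place: ethyl in place of carboxy on a saturated chain carbon, two bonds along the chain from an aromatic carbon. For the measured compounds named here, the only directly comparable step, a 1.1-fold lower number from compound 1 to compound 2 (0.06 log units; within the scatter), shows that exchanging a branched alkyl group for the acid-bearing chain made no difference beyond the scatter; the numbers of compound 1 and compound 3 likewise show that isopropyl and ethyl give values within the scatter of each other. On this basis the step of a 1.2-fold lower number from compound 2 to compound 4 (0.07 log units; within the scatter) is expected to be small, with no direction that can be trusted beyond the scatter. Compound 4 is therefore estimated at 12 nM, within a range from 4 nM to 40 nM.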

Compound 4, inhibition constant: 14 nM
Compound 4: the middle estimate sits 1.2-fold (0.07 log units) below what was measured; measured number inside the range.
By their numbers in this assay, from the lowest: compounds 3, 2, 4 and 1 (each within the scatter of the next, the first and the last beyond it).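

In this assay, exchanging 2-carboxyethyl for butyl gives no change at the digits printed from compound 2 to compound 4 (within the scatter), so removing the carboxy group, with its hydrogen-bond donor and acceptor, leaves the reading unchanged in this pair. This is a more direct test of the carboxy group than the earlier comparison of compound 2 with the branched isopropyl group. Here the chain stays unbranched and only its end is exchanged. Butyl in place of isopropyl on the same aromatic carbon gives a 1.1-fold lower number from compound 1 to compound 4 (0.06 log units; within the scatter), so in this pair the unbranched chain and the branched group cannot be told apart, and nothing available explains why these exchanges make so little difference.

The compounds shown leave open whether an amine or an amide at the end of this chain, or a chain longer than butyl, would shift the number beyond the scatter. They also leave open whether a phenyl ring on this aromatic carbon would be accommodated as readily as the chains compared here.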